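Changing the ring on the amine nitrogen

The source may report more compounds than this note shows. Statements on the series, on what has been measured and on what is new or still open speak of the compounds shown alone.

Compounds measured so far:
compound 1 `Nc1scc(CN2CCN(c3ccc(F)cc3Cl)CC2)c1C(=O)c1ccc(Cl)cc1`: -70%
compound 2 `Nc1scc(CN2CCN(c3ccc(Cl)c(C(F)(F)F)c3)CC2)c1C(=O)c1ccc(Cl)cc1`: -60%
compound 3 `Nc1scc(CN2CCN(c3ccncc3)CC2)c1C(=O)c1ccc(Cl)cc1`: -15%

All three share one core and differ only in the aromatic ring attached to the amine nitrogen in a ring. In a functional assay on CHO cells with adenosine receptor A1 (Homo sapiens) as the target, read by cAMP accumulation and immunoassay, with a stated time of 6 min, tested at 10 uM (on this read-out lower numbers stand for a stronger effect and higher numbers for a weaker effect at the one concentration tested), compound 2 stands second highest of the three numbers. Its nearest neighbour is compound 1, with a step of a number 10 percentage points higher from compound 1 to compound 2 (within the scatter), and its furthest is compound 3, with a step of a number 45 percentage points higher from compound 2 to compound 3 (beyond the scatter).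

Compound 4 `Nc1scc(CN2CCN(c3c(F)cccc3F)CC2)c1C(=O)c1ccc(Cl)cc1` is the next compound. It differs from compound 2 in one place: 2,6-difluorophenyl in place of 4-chloro-3-(trifluoromethyl)phenyl on an amine nitrogen in a ring.

Two kinds of step have been seen. Exchanging one substituted phenyl for another, from compound 1 to compound 2, gave a number 10 percentage points higher from compound 1 to compound 2 (within the scatter). Exchanging a substituted phenyl for pyridin-4-yl gave a number 55 percentage points higher from compound 1 to compound 3 (beyond the scatter) and a number 45 percentage points higher from compound 2 to compound 3 (beyond the scatter). Compound 4 keeps a six-membered aromatic ring of carbon only, so the first kind of step is the relevant one, and no step beyond the scatter is expected in this assay. Compound 4 is therefore estimated at -55%, between -78% and -25%, an expected step of a number 5 percentage points higher from compound 2 to compound 4 (within the scatter).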

Compound 4, a percentage reported as activity, at one concentration (the size of the read-out at that concentration, not a potency): -80%
The estimate for compound 4 lay 25 percentage points above the measured number, and the stated range ends above it.
By their numbers in this assay, from the lowest: compounds 4, 1 and 2 (each within the scatter of the next, the first and the last beyond it); then compound 3.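

In this assay, exchanging one carbon-only phenyl ring for another can move the result beyond the scatter, as 2,6-difluorophenyl in place of 4-chloro-3-(trifluoromethyl)phenyl gives a number 20 percentage points lower from compound 2 to compound 4 (beyond the scatter), so the substituents on this ring matter and not only the type of ring. That effect has limits: the exchange for 2-chloro-4-fluorophenyl gives a number 10 percentage points lower from compound 1 to compound 4 (within the scatter), while the exchange for pyridin-4-yl gives a much larger a number 65 percentage points lower from compound 3 to compound 4 (beyond the scatter), which confirms that the pyridine compound remains well apart from this phenyl compound. Nothing available explains why these substituent patterns differ.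

The compounds shown leave open where an unsubstituted phenyl ring would fall on this scale. They also leave open whether a phenyl ring carrying a methoxy or nitrile group would behave like the halogen-bearing rings.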